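Amide nitrogen substituent change in a kinase inhibitor series

A few compounds are considered here, and "the series" means these few. Any claim that something is new, unique, unknown or untested is made for them only; others in the source may bear on it.

Measured so far:
compound 1 `COc1cccc(CN(CCN(C)C)C(=O)c2n[nH]c3cc(-c4cn[nH]c4)ccc23)c1`: < 1 nM
compound 2 `COc1cccc(CNC(=O)c2c[nH]c3ccc(-c4cn[nH]c4)cc23)c1`: 67 nM

Both compounds were read in an assay on isolated protein for inhibition of Rho-associated protein kinase 2 (Homo sapiens), read by HTRF, with a stated time of 4 h; a higher number here means a weaker inhibitor, a lower number a stronger inhibitor. For compound 1 the value < 1 nM is a limit of the assay and not a number. Compound 1 therefore stands at the limit of < 1 nM in this assay, at which 1 of the 2 values shown sits. Among the compounds with values here, compound 2 gives 67 nM in this assay; no single-place step links compound 2 to compound 1, so the two values are simply taken as they stand and are not compared further.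

Compound 3 `COc1cccc(CN(C(=O)c2n[nH]c3cc(-c4cn[nH]c4)ccc23)C2CC2)c1` is not yet measured in this assay. It differs from compound 1 by cyclopropyl in place of 2-(dimethylamino)ethyl on an amide-type nitrogen. Within the data shown here, no measured step between a matched pair of this kind exists in the set, so the size of the expected change rests only on the position of compound 1 at the floor of the assay and on the nature of the swap. A step toward weaker inhibition, modest in size and possibly within the scatter, is expected. Compound 3 is estimated at 3 nM in this assay, with an expected range from 0.5 nM to 20 nM. The expected step is an at least 3.0-fold higher number from compound 1 to compound 3 (0.47 log units; beyond the scatter).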

Compound 3, half-maximal inhibitory concentration: 6 nM
Compound 3: the middle estimate sits 2.0-fold (0.30 log units) below what was measured, and the stated range covers the measured number.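

In this assay compound 1 gives < 1 nM, which is a limit of the assay and not a number. Cyclopropyl in place of 2-(dimethylamino)ethyl on the amide-type nitrogen gives an at least 6.0-fold higher number from compound 1 to compound 3 (0.77 log units; beyond the scatter), beyond the scatter, the first matched step in the set, so the substituent at this nitrogen is shown to change the reading while compound 3, at 6 nM, gives a number inside the range of the assay. Only a minimum can be stated for this step, and its full size stays unknown, because compound 1 sits at the limit: the limit of < 1 nM in this assay, at which 1 of the 3 values shown sits.

The compounds shown do not separate the dimethylamino end of the leaving chain from the chain itself or from the cyclopropyl ring that enters, as the swap alters all of these at once. A butyl chain or a 2-methoxyethyl chain on the same nitrogen would bear on that question, and compound 2 differs from the others in more than one place, so it adds nothing to the reading of this nitrogen.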